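Swapping the pyridine for a small pyrazole in solubility

The compounds below may be only part of what the source reports. "The series", "measured", "known", "first", "only" and "open" are said of these compounds alone.

Three compounds sharing one core were measured in a physicochemical assay for solubility, read by LC-MS, in phosphate buffer, with a stated time of 24 h, at pH 7.4; a lower number here means a less soluble compound, a higher number a more soluble compound:
compound 1 `CN(c1ccn(C)n1)c1cnc(NCc2c(F)ccc3c2CCO3)c2cn[nH]c(=O)c12` gives 12000 nM;
compound 2 `Cc1cc(-c2cnc(NCc3c(F)ccc4c3CCO4)c3cn[nH]c(=O)c23)n(C)n1` gives 1000 nM;
compound 3 `Cc1nc(CN(C)C)ccc1-c1cnc(NCc2c(F)ccc3c2CCO3)c2cn[nH]c(=O)c12` reaches only the upper limit of this assay, > 1000000 nM, so for compound 3 a limit is known and not a number.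

Compound 3 therefore stands at the top of the three, and its distance from the others is only a lower bound: an at least 83-fold higher number from compound 1 to compound 3 (1.92 log units; beyond the scatter) and an at least 1000-fold higher number from compound 2 to compound 3 (3.00 log units; beyond the scatter). Compound 4 `Cn1nccc1-c1cnc(NCc2c(F)ccc3c2CCO3)c2cn[nH]c(=O)c12` has not been measured. It differs from compound 3 in one place: 1-methyl-1H-pyrazol-5-yl in place of 6-((dimethylamino)methyl)-2-methylpyridin-3-yl on an aromatic carbon. Among the compounds with values here, the group entering is the closest relative of the one that compound 2 carries, and the step from compound 2 to compound 3 is the one that bears most directly on the change, in the opposite direction. The steps from compound 1 and compound 2 to compound 3 were both large. A large fall in this assay is therefore expected, an at least 500-fold lower number from compound 3 to compound 4 (2.69 log units; beyond the scatter), back to the region of compound 2. Compound 4 is estimated at 2000 nM, within 400 nM to 15000 nM.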

Compound 4, solubility: 2000 nM
The estimate for compound 4 equals the measured number at the digits printed; measured number inside the range.
By their numbers in this assay, from the lowest: compounds 2 and 4 (each within the scatter of the next); then compound 1. At a limit, above all of these: compound 3.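

In this assay, 1-methyl-1H-pyrazol-5-yl in place of 6-((dimethylamino)methyl)-2-methylpyridin-3-yl on this aromatic carbon gives an at least 500-fold lower number from compound 3 to compound 4 (2.69 log units; beyond the scatter), so the large gap seen with the dimethylpyrazole of compound 2 also appears with a second pyrazole. The methyl on the pyrazole carbon does not separate the two pyrazoles, whose values lie within the scatter of each other: a 2.0-fold higher number from compound 2 to compound 4 (0.30 log units; within the scatter). The step of a 6.0-fold lower number from compound 1 to compound 4 (0.78 log units; beyond the scatter) is modest and runs the same way as a 12-fold lower number from compound 1 to compound 2 (1.08 log units; beyond the scatter), so both pyrazoles carried directly on the aromatic carbon give lower numbers than the methyl(1-methyl-1H-pyrazol-3-yl)amino group of compound 1.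

On these data alone, compound 3 is known only as a limit, and how far it truly lies from the others stays open: the limit of > 1000000 nM in this assay, at which 1 of the 4 values shown sits. Also open is whether the high number goes with the pyridine ring or with its dimethylaminomethyl chain, a question that a plain 2-methylpyridin-3-yl group, or a pyrazole carrying a dimethylaminomethyl chain, would address.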